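Swapping the trimethoxyphenyl of compound 2 for dichlorophenyl

The source may hold more compounds than are shown below. What is called first, only, known or untested is meant among the compounds shown, and "the series" means these compounds.

Among the measured compounds shown here, compound 2 `COc1cc(/C=C/C(=O)c2ccc(OCCCSC(=S)N3CCN(C)CC3)cc2)cc(OC)c1OC` is the only compound here with a real number: in a functional assay on ECa-109 cells for inhibition, with ECa-109 cell line (Homo sapiens) as the target, read by MTT assay, with a stated time of 72 h (on this read-out higher numbers stand for weaker inhibition and lower numbers for stronger inhibition), compound 2 gives 7430 nM. Compound 1 `COc1ccc(/C=C/C(=O)c2ccc(OCCCSC(=S)N3CCN(C)CC3)cc2)cc1` reaches only a limit of the assay, > 100000 nM, the limit (the limit of > 100000 nM in this assay, at which 1 of the 2 values shown sits). For the measured compounds named here, the one measured step, an at least 13-fold lower number from compound 1 to compound 2 (1.12 log units; beyond the scatter), shows how much the aryl group matters. Compound 3 `CN1CCN(C(=S)SCCCOc2ccc(C(=O)/C=C/c3cc(Cl)cc(Cl)c3)cc2)CC1` carries 3,5-dichlorophenyl in place of 3,4,5-trimethoxyphenyl on a double-bonded chain carbon bound to a double-bonded chain carbon. Going by the values given here, since the same position carried the only large step, the change from compound 2 to compound 3 is expected to be sizable and toward weaker inhibition, about a 4.0-fold higher number from compound 2 to compound 3 (0.61 log units; beyond the scatter). Compound 3 is therefore estimated at 30000 nM, between 7000 nM and 100000 nM.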

Compound 3, half-maximal inhibitory concentration: 12400 nM
The estimate for compound 3 lay 2.4-fold (0.38 log units) above the measured number; measured number inside the range.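

With a 1.7-fold higher number from compound 2 to compound 3 (0.22 log units; within the scatter), 3,5-dichlorophenyl and 3,4,5-trimethoxyphenyl cannot be told apart at this position, so the methoxy groups are not required to hold this level of inhibition, even though no oxygen remains on the ring. A clear difference from 4-methoxyphenyl also survives with this quite different group, an at least 8.0-fold lower number from compound 1 to compound 3 (0.90 log units; beyond the scatter). That step starts from a limit for compound 1, not from a true number: the limit of > 100000 nM in this assay, at which 1 of the 3 values shown sits. The compounds shown leave open whether an unsubstituted phenyl or a 3,5-dimethoxyphenyl group would hold the same level.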